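Methoxy on the pendant ring, measured near the assay ceiling

The source may report more compounds than this note shows. Statements on the series, on what has been measured and on what is new or still open speak of the compounds shown alone.

Three compounds sharing a core were tested in a functional assay on HepG2 cells (Homo sapiens) for inhibition, read by MTT assay, with a stated time of 48 h; on this read-out higher numbers stand for weaker inhibition and lower numbers for stronger inhibition. Compound 2 `Fc1ccc(/C=N/Nc2nc(-c3ccccc3)cs2)cc1F` carries a plain phenyl on that core; in this assay compound 2 gives only a limit, > 100000 nM. Compound 1 `COc1ccccc1-c1csc(N/N=C/c2ccc(F)c(F)c2)n1` differs from compound 2 by methoxy in place of hydrogen on an aromatic carbon; in this assay compound 1 likewise gives only a limit, > 100000 nM. The step that the two limits leave unreadable from compound 2 to compound 1 therefore has no readable size, since both values sit at the limit of > 100000 nM in this assay, at which 2 of the 3 values shown sit. For the measured compounds named here, compound 3 `COc1cc(/C=N/Nc2nc(-c3ccccc3)cs2)cc(Br)c1OC` differs from compound 2 in more than one place, and the difference between the two cores is not broken down here; in this assay compound 3 gives 68300 nM, the only number among the three measured values. Compound 4 `COc1ccccc1-c1csc(N/N=C/c2cc(Br)c(OC)c(OC)c2)n1` has not yet been measured. It differs from compound 3 by methoxy in place of hydrogen on an aromatic carbon, the same change as from compound 2 to compound 1, and that earlier step was unreadable. Compound 3 stands at 68300 nM in this assay. Compound 4 is expected to show a step of about a 1.2-fold higher number from compound 3 to compound 4 (0.07 log units; within the scatter), within the scatter. Compound 4 is thus estimated at 80000 nM, most likely between 30000 nM and 200000 nM, with a real chance that only a limit is reported.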

Compound 4, half-maximal inhibitory concentration: 82100 nM
For compound 4 the middle estimate is 1.0-fold (0.01 log units) below the measured one; measured number inside the range.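

In this assay, replacing phenyl with 2-methoxyphenyl on the core of compound 3 gives a 1.2-fold higher number from compound 3 to compound 4 (0.08 log units; within the scatter), so on this core the change leaves the number within the usual scatter of repeated measurements. The same change from compound 2 to compound 1 cannot be read, and both of those compounds give only a limit of the assay: the limit of > 100000 nM in this assay, at which 2 of the 4 values shown sit. This leaves a single readable step, which does not show that the change carries from one core to another, since there is no second size to set beside it, and it does not show that the methoxy is without consequence on the core of compound 1.

On these data alone, whether an amine or a carboxylic acid in place of the methoxy on that phenyl would give a number beyond the scatter of compound 3 remains open. Also open, as far as these compounds go, is how the change would read on a core whose parent gives a number well clear of the limit in this assay.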